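Swapping a halogen on an anilino ring: an expected small step

The compounds below may be only part of what the source reports. "The series", "measured", "known", "first", "only" and "open" are said of these compounds alone.

Three related compounds have been tested in a functional assay on PC-3 cells (Homo sapiens) for inhibition, read by MTT assay, with a stated time of 72 h; on this read-out higher numbers stand for weaker inhibition and lower numbers for stronger inhibition. Compound 1, with the structure `O=C(CSc1nc(Nc2ccccc2)c2ccccc2n1)Nc1cccc(Cl)c1`, gives 12600 nM. Compound 2, with the structure `O=C(CSc1nc(Nc2ccccc2)c2ccccc2n1)Nc1cccc(Br)c1`, differs from it by a single change, (bromo in place of chloro on an aromatic carbon), and in this assay compound 2 gives 11400 nM. The resulting step, a 1.1-fold lower number from compound 1 to compound 2 (0.04 log units; within the scatter), is one that repeated measurements of this kind could produce on their own.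

Compound 3, with the structure `C=CC(=O)Nc1cccc(NC(=O)CSc2nc(Nc3ccccc3Cl)c3ccccc3n2)c1`, gives 14400 nM in this assay. Its core differs from that of compound 1 in more than one place, and the difference between the two cores is not broken down here; the two values sit within the usual scatter of each other.

Compound 4, with the structure `C=CC(=O)Nc1cccc(NC(=O)CSc2nc(Nc3ccccc3Br)c3ccccc3n2)c1`, has not been measured. It is related to compound 3 by bromo in place of chloro on an aromatic carbon. Among the measured compounds shown here, this is the same kind of change as the one from compound 1 to compound 2, though not the same: in the earlier pair the halogen sits meta to a large group, whereas here it sits ortho to a large group. Given that the earlier swap produced only a 1.1-fold lower number from compound 1 to compound 2 (0.04 log units; within the scatter), the step from compound 3 to compound 4 is expected to be small, about a 1.1-fold lower number from compound 3 to compound 4 (0.04 log units; within the scatter). Compound 4 is therefore estimated to give 13000 nM, with a plausible range from 7000 nM to 25000 nM, an expectation resting on compound 3 at 14400 nM.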

Compound 4, half-maximal inhibitory concentration: 17100 nM
The estimate for compound 4 lay 1.3-fold (0.12 log units) below the measured number, and the stated range covers the measured number.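

In this assay, placing bromo instead of chloro on the (2-chlorophenyl)amino group of compound 3 gives a 1.2-fold higher number from compound 3 to compound 4 (0.07 log units; within the scatter), so this pair cannot be told apart on this read-out. Carried from one core to the other, the swap therefore gives the same answer on both, as far as the measurements can tell: the same change on two cores in this assay, a 1.1-fold lower number (0.04 log units; within the scatter) from compound 1 to compound 2 and a 1.2-fold higher number (0.07 log units; within the scatter) from compound 3 to compound 4, 1.3-fold (0.12 log units) apart, within the scatter of two such steps. Among the compounds shown here, this shows that on these two cores, exchanging one of these halogens for the other leaves no step beyond the usual scatter, but with only two pairs it does not show that the swap is harmless on every core, nor does it explain why the numbers behave this way.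

The compounds shown carry only chloro or bromo in these places, so it remains open whether a different group there, such as an amine, a methoxy group or a carboxylic acid, would give a step beyond the scatter. On these data alone, it also remains open whether the same halogen swap would stay this small on a third core, or on compounds with much lower numbers in this assay than those seen here.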